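This account rests on a few compounds, and the source may have more. Where it says the series, first, only, none or still open, it means among the compounds named here.

Compound 1 `CCCCCCCCCNC(=O)[C@H]1OC(n2cnc3c(N)ncnc32)[C@H](O)[C@@H]1O` — 31 nM
Compound 2 `NCCCCCCCCNC(=O)[C@H]1OC(n2cnc3c(N)ncnc32)[C@H](O)[C@@H]1O` — 29 nM
Compound 3 `CC(=O)NCCNC(=O)[C@H]1OC(n2cnc3c(N)ncnc32)[C@H](O)[C@@H]1O` — 46 nM

These three compounds share one core and differ only in the group carried on the amide-type nitrogen. All were tested in an assay on cell membranes for binding affinity to 2-oxoglutarate receptor 1 (Rattus norvegicus), read by radioligand binding; on this read-out lower numbers stand for stronger inhibition and higher numbers for weaker inhibition. Compound 3 has the highest number of the three, but neither of its neighbours is separated from it by more than the scatter: a 1.5-fold higher number from compound 1 to compound 3 (0.17 log units; within the scatter) and a 1.6-fold higher number from compound 2 to compound 3 (0.20 log units; within the scatter). Compound 4 `Nc1ncnc2c1ncn2C1O[C@H](C(=O)NC2CC3CCC2C3)[C@@H](O)[C@H]1O` has not yet been measured. It differs from compound 3 in a group of 7 heavy atoms (7 carbon; 2 five-membered non-aromatic rings of carbon only) in place of a group of 6 heavy atoms (4 carbon, 1 nitrogen, 1 oxygen; no ring), on an amide-type nitrogen. The measured steps that bear on this change are the three that swap one group for another on that same nitrogen: the two just named and a 1.1-fold lower number from compound 1 to compound 2 (0.03 log units; within the scatter). Each stayed within the scatter, although none introduced a ring, so the exchange in compound 4 is partly untested. On this evidence compound 4 is expected to give about 35 nM in this assay, with a range from 12 nM to 110 nM. The expected step is a 1.3-fold lower number from compound 3 to compound 4 (0.12 log units; within the scatter), with no direction beyond the scatter predicted.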

Compound 4, inhibition constant: 640 nM
Compound 4: the middle estimate sits 18-fold (1.26 log units) below what was measured; measured number outside the range, above it.
By their numbers in this assay, from the lowest: compounds 2, 1 and 3 (each within the scatter of the next); then compound 4.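

This result shows that the amide-type nitrogen does not accept every group equally: the group with two carbon rings in compound 4 weakens binding against the 2-acetamidoethyl group (a 14-fold higher number from compound 3 to compound 4 (1.14 log units; beyond the scatter)) and against the two longer open chains (a 22-fold higher number from compound 2 to compound 4 (1.34 log units; beyond the scatter)) and (a 21-fold higher number from compound 1 to compound 4 (1.31 log units; beyond the scatter)). An all-carbon group alone does not go with this loss, as the nonyl group of compound 1 is also all carbon and its number lies within the scatter of those of compound 2 and compound 3. Nothing measured here explains the loss.

The compounds shown leave open whether a single ring, such as cyclopentyl or cyclohexyl, would give a similar step or whether it takes both rings. They also leave open how a short open chain, such as ethyl or propyl, would compare.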